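Hydroxy in place of hydrogen on compound 1

This account rests on a few compounds, and the source may have more. Where it says the series, first, only, none or still open, it means among the compounds named here.

Measured so far in a functional assay on Hs-578T cells (Homo sapiens) for inhibition; on this read-out higher numbers stand for weaker inhibition of growth and lower numbers for stronger inhibition of growth
- compound 1 `COc1ccc(-n2cnnc2-c2cc(OC)c(OC)c(OC)c2)cc1` gives 2950 nM
- compound 2 `COc1cc(-c2nncn2-c2ccc(N(C)C)cc2)cc(OC)c1OC` gives 417 nM

Compound 1 holds the higher of the two numbers in this assay and thus shows the weaker inhibition of growth. Compound 3 `COc1ccc(-n2cnnc2-c2cc(OC)c(OC)c(OC)c2)cc1O` has not been measured and differs from compound 1 by hydroxy in place of hydrogen on an aromatic carbon on the same core. Among the measured compounds shown here, the only measured step, a 7.1-fold lower number from compound 1 to compound 2 (0.85 log units; beyond the scatter), is dimethylamino in place of methoxy, a different change, so it offers only loose guidance. A step of similar size towards a lower number is expected, namely a 9.8-fold lower number from compound 1 to compound 3 (0.99 log units; beyond the scatter) as estimated. For compound 3 the estimate is 300 nM, with an expected range from 30 nM to 3000 nM in this assay.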

Compound 3, concentration for 50% growth inhibition: 363 nM
Compound 3: middle estimate off by 1.2-fold (0.08 log units), on the low side, and the stated range covers the measured number.
By their numbers in this assay, from the lowest: compounds 3 and 2 (each within the scatter of the next); then compound 1.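

Hydroxy in place of hydrogen on the aromatic carbon ortho to a methoxy group gives an 8.1-fold lower number from compound 1 to compound 3 (0.91 log units; beyond the scatter) in this assay. The number therefore also responds at this carbon, with the methoxy group kept, whereas the earlier step changed the methoxy group itself. No available evidence bears on the reason for this step. Still open, on these data alone, is whether an amine, fluorine or a methoxy group on this same carbon would lower the number as hydroxy does. Also open, as far as these compounds go, is whether the hydroxy step would hold with dimethylamino in place of the methoxy group.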